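Swapping the chlorophenyl for a chloropyridinyl on the piperidine arm

A few compounds are considered here, and "the series" means these few. Any claim that something is new, unique, unknown or untested is made for them only; others in the source may bear on it.

Measured compounds:
compound 1 `Cc1ccc2c(NCc3ccc(NC(=O)C4CCN(Cc5ccc(Cl)cc5)CC4)cc3)nc(N(C)C)nc2c1` gives > 3180 nM in a functional assay on SV5A8 cells (Homo sapiens) for cytotoxicity; on this read-out lower numbers stand for stronger inhibition and higher numbers for weaker inhibition
compound 2 `Cc1ccc2c(NCc3ccc(NC(=O)C4CCN(Cc5ccccc5)CC4)cc3)nc(N3CCCC3)nc2c1` gives > 7790 nM in this assay

Both values are limits of this assay and not numbers. Compound 1 stands at the limit of > 3180 nM in this assay, at which 1 of the 2 values shown sits, so nothing places it above or below compound 2. Compound 3 `Cc1ccc2c(NCc3ccc(NC(=O)C4CCN(Cc5cc(Cl)ccn5)CC4)cc3)nc(N(C)C)nc2c1` has not yet been measured. It differs from compound 1 by 4-chloropyridin-2-yl in place of 4-chlorophenyl on a saturated chain carbon bound to an amine nitrogen in a ring. Within the data shown here, with no measured step between the two compounds, the expected change a step that the limit leaves unreadable from compound 1 to compound 3 is none beyond the scatter. Compound 3 is therefore estimated to give 5000 nM, within 2000 nM to 15000 nM, most likely again as a limit.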

Compound 3, half-maximal inhibitory concentration: > 5400 nM
Compound 3: a limit, no number; the forecaster's own chance of this, stated with the estimate: 80%; middle value at least 1.0-fold (0.03 log units) from the limit.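

Compound 1 and compound 3 both give limits rather than numbers in this assay, so no step can be read between them. From the compounds shown here alone, whether 4-chloropyridin-2-yl in place of 4-chlorophenyl changes the read-out at all stays open.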